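The compounds below may be only part of what the source reports. "The series", "measured", "known", "first", "only" and "open" are said of these compounds alone.

Of the compounds shown here, three built on one shared core have been measured in an in vitro functional assay on cells for agonist activity at Bombesin receptor subtype-3 (Mus musculus), read by luminescence and calcium flux; a lower number here means that less compound is needed, a higher number that more compound is needed for the effect. Compound 1 `O=C(O)c1ccccc1-c1ccc(CCc2ncc(C3CCCCC3)[nH]2)cc1` gives 14.7 nM. Compound 2 `Cc1cccc(Cc2cnc(CCc3ccc(-c4ccccc4C(=O)O)cc3)[nH]2)c1` gives 75 nM, and compound 3 `O=C(O)c1ccccc1-c1ccc(CCc2ncc(CC3CC3)[nH]2)cc1` gives 72 nM. Among these three numbers compound 3 holds the second highest: its nearest neighbour is compound 2, and compound 1 lies furthest from it. The two steps that lead to compound 3 are a 4.9-fold higher number from compound 1 to compound 3 (0.69 log units; beyond the scatter) and a 1.0-fold lower number from compound 2 to compound 3 (0.02 log units; within the scatter).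

Compound 4 `O=C(O)c1ccccc1-c1ccc(CCc2ncc(Cc3cccc(Cl)c3)[nH]2)cc1` has not yet been tested. Relative to compound 3 it carries 3-chlorophenyl in place of cyclopropyl on a saturated chain carbon bound to an aromatic carbon. The measured step that bears most directly on this change is a 1.0-fold lower number from compound 2 to compound 3 (0.02 log units; within the scatter): a 3-methylphenyl and a 3-chlorophenyl are both six-membered aromatic rings carrying one small substituent, so compound 2 is the closest measured relative of compound 4. Neither of these aromatic groups resembles the cyclohexyl of compound 1, whose replacement gave a 5.1-fold higher number from compound 1 to compound 2 (0.71 log units; beyond the scatter) and a 4.9-fold higher number from compound 1 to compound 3 (0.69 log units; beyond the scatter). Compound 4 is therefore expected to land close to compound 2 and compound 3, with no step beyond the scatter. The expected step is a 1.0-fold lower number from compound 3 to compound 4 (0.01 log units; within the scatter). For compound 4 in this assay the estimate is 70 nM, with a range from 30 nM to 170 nM.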

Compound 4, half-maximal effective concentration: 31 nM
Estimate against measurement, compound 4: 2.3-fold (0.35 log units) above, and the stated range covers the measured number.
By their numbers in this assay, from the lowest: compound 1; then compound 4; then compounds 3 and 2 (each within the scatter of the next).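

In this assay, 3-chlorophenyl in place of cyclopropyl on a saturated chain carbon bound to an aromatic carbon gives a 2.3-fold lower number from compound 3 to compound 4 (0.37 log units; beyond the scatter) and shows that this position can tell these two groups apart, which the closely matched compound 2 and compound 3 had not suggested. The exchange of chloro for methyl on an aromatic carbon gives a 2.4-fold lower number from compound 2 to compound 4 (0.38 log units; beyond the scatter) and shows that a single small substituent on the aromatic ring can change the number even when the rest of the molecule stays the same, while 3-chlorobenzyl in place of cyclohexyl gives a 2.1-fold higher number from compound 1 to compound 4 (0.32 log units; beyond the scatter) and leaves cyclohexyl with the lowest number of the four. No measurement here explains these differences.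

Only chloro and methyl have been compared on this aromatic ring, so the results cannot show how a plain benzyl group, or a fluoro, methoxy or trifluoromethyl group in place of the chloro, would behave. Going by these compounds, it also remains open whether a saturated ring larger than cyclohexyl, or a cyclohexylmethyl group, would give a number lower than that of compound 1.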